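A few compounds are considered here, and "the series" means these few. Any claim that something is new, unique, unknown or untested is made for them only; others in the source may bear on it.

Compound 1 `COc1cc(-c2nn(-c3cccc(NC(=O)Nc4cc(C(F)(F)F)cc(C(F)(F)F)c4)c3)cc2-c2ccncc2)ccc1Cl` gives 3140 nM in a functional assay on CAKI-1 cells (Homo sapiens) for inhibition, read by sulforhodamine B assay, with a stated time of 48 h; on this read-out higher numbers stand for weaker inhibition of growth and lower numbers for stronger inhibition of growth. Compound 2 `O=C(Nc1cccc(-n2cc(-c3ccncc3)c(-c3ccc(Cl)c(O)c3)n2)c1)Nc1cc(C(F)(F)F)cc(C(F)(F)F)c1` carries hydrogen in place of methyl on an oxygen on an aromatic ring and gives 4420 nM in this assay; the step is a 1.4-fold higher number from compound 1 to compound 2 (0.15 log units; within the scatter). Compound 3 `COc1cc(-c2nn(-c3cccc(NC(=O)Nc4ccc(Cl)c(C(F)(F)F)c4)c3)cc2-c2ccncc2)ccc1Cl` gives 4720 nM in this assay; the difference between the core of compound 3 and the core of compound 1 is not broken down here, and the values of compound 3 and compound 1 lie within the scatter of each other. Within the data shown here, compound 4 `O=C(Nc1cccc(-n2cc(-c3ccncc3)c(-c3ccc(Cl)c(O)c3)n2)c1)Nc1ccc(Cl)c(C(F)(F)F)c1` differs from compound 3 by hydrogen in place of methyl on an oxygen on an aromatic ring, the same change as the one between compound 1 and compound 2, at the same place. Because the earlier step was a 1.4-fold higher number from compound 1 to compound 2 (0.15 log units; within the scatter), a step of similar size, a 1.3-fold higher number from compound 3 to compound 4 (0.10 log units; within the scatter), is expected in this assay. Compound 4 is accordingly estimated at 6000 nM, with a range from 3000 nM to 12000 nM.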

Compound 4, concentration for total growth inhibition: 2630 nM
The estimate for compound 4 lay 2.3-fold (0.36 log units) above the measured number, outside the stated range (below it).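

Replacing methoxy with hydroxy in this assay gives a 1.8-fold lower number from compound 3 to compound 4 (0.25 log units; within the scatter), and this step cannot be told apart from the earlier one on the other core: the same change on two cores in this assay, a 1.4-fold higher number (0.15 log units; within the scatter) from compound 1 to compound 2 and a 1.8-fold lower number (0.25 log units; within the scatter) from compound 3 to compound 4, 2.5-fold (0.40 log units) apart, within the scatter of two such steps. In both pairs the change stays within the scatter, so these two cores give no sign that its effect depends on the core. Among these compounds, this does not show that the change is neutral on other cores or in other assays, as only two pairs in one assay are available.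

Still open, as far as these compounds go, is whether a different group at this oxygen, such as an ethyl ether or a longer chain, would move the number beyond the scatter. From the compounds shown here alone, an amine in place of the hydroxy is equally open.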